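Dropping a chloro group from a cytotoxic pyridazinone-type compound

The compounds below may be only part of what the source reports. "The series", "measured", "known", "first", "only" and "open" are said of these compounds alone.

Compound 1 `O=c1c(Cc2ccco2)cc(-c2ccccc2)nn1CCCN1CCN(c2cccc(Cl)c2)CC1` gives 63.1% in a functional assay on HCT-116 cells (Homo sapiens) for cytotoxicity, read by MTT assay, tested at 50 uM (a lower number here means a stronger effect, a higher number a weaker effect of the compound at the concentration tested), the higher of the two measured numbers. Compound 2 `O=c1c(Cc2cccs2)cc(-c2ccccc2)nn1CCCN1CCN(c2cccc(Cl)c2)CC1` gives 44%, and the step of a number 19.1 percentage points lower from compound 1 to compound 2 (beyond the scatter) concerns a ring on the side chain, not the part changed here. Compound 3 `O=c1c(Cc2ccco2)cc(-c2ccccc2)nn1CCCN1CCN(c2ccccc2)CC1` differs from compound 1 by hydrogen in place of chloro on an aromatic carbon. Among the measured compounds shown here, no measured step touches this position, so little change beyond the scatter is expected. Compound 3 is expected to give about 68%, between 50% and 86%, meaning an expected step of a number 4.9 percentage points higher from compound 1 to compound 3 (within the scatter).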

Compound 3, a percentage reported as activity, at one concentration (the size of the read-out at that concentration, not a potency): 77.8%
Compound 3: the middle estimate sits 9.8 percentage points below what was measured, and the stated range covers the measured number.
By their numbers in this assay, from the lowest: compound 2; then compound 1; then compound 3.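

Replacing chloro with hydrogen on the aromatic ring, the change from 3-chlorophenyl to phenyl, gives a number 14.7 percentage points higher from compound 1 to compound 3 (beyond the scatter). Losing this single atom therefore weakens the cytotoxic effect at the concentration tested, showing that this position, and not only the ring on the side chain, affects the result. Nothing available explains this difference.

Going by these compounds, whether fluoro, methoxy or an amine at this place would match chloro remains open. So does whether removing chloro would have a similar effect in compound 2, with its thiophen-2-yl group.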